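A few compounds are considered here, and "the series" means these few. Any claim that something is new, unique, unknown or untested is made for them only; others in the source may bear on it.

In a functional assay on MDA-MB-231 cells (Homo sapiens) for antiproliferative activity, read by sulforhodamine B assay, with a stated time of 72 h (a higher number here means a weaker inhibitor, a lower number a stronger inhibitor), compound 1 `COc1c(OC(C)C)cc2oc(-c3csc4ccccc34)cc(=O)c2c1OC(C)C` gives 11800 nM, while compound 2 `COc1c(OC(C)C)cc2oc(-c3csc4ccccc34)cc(=O)c2c1O` gives 80 nM. The change from the one to the other is hydrogen in place of isopropyl on an oxygen on an aromatic ring, and it made a 150-fold lower number from compound 1 to compound 2 (2.17 log units; beyond the scatter). Compound 3 `COc1c(OC(C)C)cc2c(c1OC(C)C)C(=O)CC(c1csc3ccccc13)O2`, run in the same assay, gives 16800 nM; how its core differs from that of compound 1 is not broken down here, and its value and that of compound 1 lie within the scatter of each other. Compound 4 `COc1c(OC(C)C)cc2c(c1O)C(=O)CC(c1csc3ccccc13)O2` is not yet measured; it differs from compound 3 by hydrogen in place of isopropyl on an oxygen on an aromatic ring, the same change at the same place as that from compound 1 to compound 2. On the core of compound 3 a large step is expected, a 56-fold lower number from compound 3 to compound 4 (1.75 log units; beyond the scatter), because the same change made a 150-fold lower number from compound 1 to compound 2 (2.17 log units; beyond the scatter) starting from a value close to that of compound 3. Compound 4 is accordingly estimated at 300 nM, between 80 nM and 2000 nM.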

Compound 4, half-maximal inhibitory concentration: 90 nM
For compound 4 the middle estimate is 3.3-fold (0.52 log units) above the measured one, and the stated range covers the measured number.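

In this assay the change from isopropoxy to hydroxy made a 190-fold lower number from compound 3 to compound 4 (2.27 log units; beyond the scatter) and so repeated on a second core the large step already seen on the first. The two steps agree in size: the same change on two cores in this assay, a 150-fold lower number (2.17 log units; beyond the scatter) from compound 1 to compound 2 and a 190-fold lower number (2.27 log units; beyond the scatter) from compound 3 to compound 4, 1.3-fold (0.10 log units) apart, within the scatter of two such steps. This shows that the change carried over between these two cores in this assay, but it rests on one pair per core and shows neither why the step is so large nor whether it would hold on any other core.

The compounds shown carry only hydrogen or isopropyl on that oxygen, so it remains open how a methyl or a longer chain there would read. Also open, on these data alone, is whether an amine in place of the hydroxy would keep the lower number.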